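Aryl swap on the thiadiazole-linked pyridazinone insecticide series

The compounds below may be only part of what the source reports. "The series", "measured", "known", "first", "only" and "open" are said of these compounds alone.

Measured so far:
- compound 1 `CC(C)(C)n1ncc(OCc2nnc(-c3ccc(Cl)cc3Cl)s2)c(Cl)c1=O`: 62.2 ug/mL
- compound 2 `CC(C)(C)n1ncc(OCc2nnc(-c3ccccc3Cl)o2)c(Cl)c1=O`: 61.2 ug/mL
- compound 3 `CCCCn1ncc(OCc2nnc(-c3ccccc3)o2)c(Cl)c1=O`: limit, > 300 ug/mL

In a functional assay on the whole organism for inhibition, with Mythimna separata as the target, with a stated time of 5 days (on this read-out lower numbers stand for an effect already at smaller amounts and higher numbers for an effect only at larger amounts of compound), compound 1 gives 62.2 ug/mL and compound 2 gives 61.2 ug/mL; the two numbers sit within the usual scatter of each other, so no order between them can be read. For compound 3 this assay yields only a limit, > 300 ug/mL, which is the value at which the shown measurements of this kind stop (the limit of > 300 ug/mL in this assay, at which 1 of the 3 values shown sits). Among the two compounds that give an actual number, compound 1 is thus one of two equivalent values rather than a clear best or worst.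

Compound 4 `Cc1cc(C)cc(-c2nnc(COc3cnn(C(C)(C)C)c(=O)c3Cl)s2)c1` differs from compound 1 in one place: 3,5-dimethylphenyl in place of 2,4-dichlorophenyl on an aromatic carbon. Going by the values given here, no pair of measured compounds shares this same change, so no measured step sets its size. The two aryl groups match in atom count, donors and acceptors, and only the ring substituents trade places.

Against that background the step from compound 1 to compound 4 is expected to be small, a 1.4-fold higher number from compound 1 to compound 4 (0.14 log units; within the scatter), with a modest loss judged more likely than a gain but neither clearly beyond the scatter. Compound 4 is therefore estimated at 85 ug/mL in this assay, with a range from 30 ug/mL to 250 ug/mL.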

Compound 4, half-maximal effective concentration: > 300 ug/mL
Compound 4 was reported as a limit; the forecaster's own chance of this, stated with the estimate: 25%; middle value at least 3.5-fold (0.54 log units) from the limit.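

The aryl group on the aromatic carbon of the five-membered ring, next to the ring nitrogen and the ring sulfur, proves to be a position where the choice of substituents matters in this assay: 3,5-dimethylphenyl in place of 2,4-dichlorophenyl gives an at least 4.8-fold higher number from compound 1 to compound 4 (0.68 log units; beyond the scatter). Going by these compounds alone, the two aryl groups match in heavy-atom count, ring type, hydrogen-bond donors and acceptors and charge, so these counts alone do not predict the read-out at this position, and the step is the first one to show a change that can be read. Compound 4 gives > 300 ug/mL, which is a limit and not a number, so the step fixes only a lower bound on the loss and its full size stays unknown: the limit of > 300 ug/mL in this assay, at which 2 of the 4 values shown sit.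

The compounds shown do not separate the swap of chlorine for methyl from the change in where the ring substituents sit, since both differ at once between these two aryl groups. On these data alone, how a methoxy or a trifluoromethyl group on the same phenyl ring would read out at this position also remains open.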